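Swapping fluoro for methoxy on a weakly active ketone

The source may hold more compounds than are shown below. What is called first, only, known or untested is meant among the compounds shown, and "the series" means these compounds.

Compound 1, `COc1ccc(C(=O)CSc2nc3ccccc3[nH]2)cc1OC`, gives 19100 nM in a functional assay on HT-29 cells (Homo sapiens) for inhibition, read by WST assay, with a stated time of 48 h; on this read-out lower numbers stand for stronger inhibition and higher numbers for weaker inhibition.
Compound 2, `O=C(CSc1nc2ccccc2[nH]1)c1ccc(F)cc1`, gives 78700 nM in this assay.
Compound 3, `COc1ccccc1C(=O)CSc1nc2ccccc2[nH]1`, gives 36100 nM in this assay.

All three share the same core and differ only in what sits on the aryl ketone ring. Compound 2 carries the highest number of the three, meaning the weakest inhibition. Its nearest neighbour is compound 3, whose number is lower by an amount beyond the usual scatter, and compound 1 lies further off with a lower number still.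

Compound 4, `COc1ccc(C(=O)CSc2nc3ccccc3[nH]2)cc1`, has not yet been measured. It differs from compound 2 in one place: methoxy in place of fluoro on an aromatic carbon.

Going by the values given here, no pair of measured compounds differs in exactly one place, so nothing measured shows the size of this particular swap directly. What can be said is that the two measured compounds bearing methoxy, compound 1 with 19100 nM and compound 3 with 36100 nM, both sit at lower numbers than compound 2 in this assay. On that basis a move to a lower number, modest but beyond the scatter, is expected. Compound 4 is therefore estimated at about 30000 nM, within a range of 12000 nM to 75000 nM. The step this estimate implies is a 2.6-fold lower number from compound 2 to compound 4 (0.42 log units; beyond the scatter).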

Compound 4, half-maximal inhibitory concentration: 25200 nM
Beside the measured number, compound 4's estimate is 1.2-fold (0.08 log units) above it; the measured number falls inside the stated range.
By their numbers in this assay, from the lowest: compounds 1, 4 and 3 (each within the scatter of the next); then compound 2.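

In this assay, the swap of fluoro for methoxy, on an aromatic carbon para to a large group, now has a measured size: a 3.1-fold lower number from compound 2 to compound 4 (0.49 log units; beyond the scatter). Going by these compounds alone, this is the first direct reading of the change, since the earlier compounds could only hint at it from compounds that differed in more than one place. Within the data shown here, compound 1 and compound 4 also turn out to differ in one place, hydrogen in place of the second methoxy of compound 1, and a 1.3-fold higher number from compound 1 to compound 4 (0.12 log units; within the scatter), so that second methoxy has no effect that can be told apart from the scatter, and the single methoxy of compound 4 is enough for a number in this range. Nothing measured here explains why methoxy and fluoro part in this way.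

The compounds shown leave open whether this step is particular to methoxy or would also come with another group on the same carbon, such as an amine, a hydroxyl or a longer chain like ethoxy. They also leave open how a compound with plain hydrogen at this carbon would compare with compound 2 and compound 4.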